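One benzyl swap, measured once, expected again

The source may report more compounds than this note shows. Statements on the series, on what has been measured and on what is new or still open speak of the compounds shown alone.

Compound 2 `Fc1ccc(Cc2ccc3c(NCCCNCc4ccco4)ccnc3c2)cc1` carries a furan-2-yl group on a saturated chain carbon bound to an amine nitrogen and a 4-fluorophenyl group on a saturated chain carbon bound to an aromatic carbon. In a physicochemical assay for acid dissociation, compound 2 gives 9.47. Compound 1 `Cc1cc(C)cc(Cc2ccc3c(NCCCNCc4ccco4)ccnc3c2)c1` differs from it by 3,5-dimethylphenyl in place of 4-fluorophenyl on a saturated chain carbon bound to an aromatic carbon, and the step of no change at the digits printed from compound 2 to compound 1 (within the scatter). Compound 3 `COc1ccc(F)cc1CNCCCNc1ccnc2cc(Cc3ccc(F)cc3)ccc12` differs from compound 2 by 5-fluoro-2-methoxyphenyl in place of furan-2-yl on a saturated chain carbon bound to an amine nitrogen; in this assay compound 3 gives 9.47, and the step of no change at the digits printed from compound 2 to compound 3 (within the scatter). In this assay compound 1 gives 9.47, level with compound 3.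

Compound 4 `COc1ccc(F)cc1CNCCCNc1ccnc2cc(Cc3cc(C)cc(C)c3)ccc12` has not yet been measured. It differs from compound 3 by 3,5-dimethylphenyl in place of 4-fluorophenyl on a saturated chain carbon bound to an aromatic carbon, the same change already made from compound 2 to compound 1, where the step was no change at the digits printed from compound 2 to compound 1 (within the scatter). The place of the change is the same in both cases. The expected step is no change at the digits printed from compound 3 to compound 4 (within the scatter), because that earlier step showed no change at the digits printed from compound 2 to compound 1 (within the scatter). Compound 4 is therefore expected to give 9.47 in this assay, between 9.2 and 9.75.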

Compound 4, acid dissociation constant: 9.47
Compound 4: the middle estimate sits on the measured number at the digits printed; the range from low to high includes it.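

In this assay, the change from 4-fluorobenzyl to 3,5-dimethylbenzyl gives no change at the digits printed from compound 3 to compound 4 (within the scatter), matching the earlier no change at the digits printed from compound 2 to compound 1 (within the scatter), and the other route around the same set of four compounds gives no change at the digits printed from compound 1 to compound 4 (within the scatter), so in this small square the change reads the same whether the amine side carries furan-2-yl or 5-fluoro-2-methoxyphenyl. For the compounds shown here, this shows only that a step of no visible size stayed that way across two pairs; since all four readings are level, it cannot show that a step of real size would carry from one compound to another in the same way. Nothing here gives a measured reason for the level readings.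

The compounds shown leave open whether the reading would stay level with a carboxylic acid or an amine on the benzyl group. They also leave open what a longer chain in place of the present one would do to it.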